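The compounds below may be only part of what the source reports. "The series", "measured", "known", "first", "only" and "open" are said of these compounds alone.

In an ADME assay on HepG2 cells (Homo sapiens) for cytotoxicity, with a stated time of 72 h (on this read-out lower numbers stand for an effect already at smaller amounts and higher numbers for an effect only at larger amounts of compound), three compounds have been measured:
Compound 1 (`Cc1ccc(-c2nc3ccccc3s2)cc1NC(=O)c1cc([N+](=O)[O-])c(N2CCC(C(=O)O)CC2)cc1Cl`) gives > 25000 nM as a limit.
Compound 2 (`COC(=O)C1CCN(c2cc(Cl)c(C(=O)Nc3cc(-c4nc5ccccc5s4)ccc3C)cc2[N+](=O)[O-])CC1`) gives > 25000 nM as a limit.
Compound 3 (`Cc1ccc(-c2nc3ccccc3s2)cc1NC(=O)c1cc([N+](=O)[O-])c(N2CCCCC2)cc1Cl`) gives > 25000 nM as a limit.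

Compound 1 therefore stands at a limit and not at a number, and so do the other two: the limit of > 25000 nM in this assay, at which 3 of the 3 values shown sit, is all that the set shows. Compound 4 (`COc1ccc(-c2nc3ccccc3s2)cc1NC(=O)c1cc([N+](=O)[O-])c(N2CCC(C(=O)O)CC2)cc1Cl`) differs from compound 1 in one place, with methoxy in place of methyl on an aromatic carbon, ortho to a large group and para to a 1,3-benzothiazol-2-yl group: methoxy in place of methyl on an aromatic carbon is the whole change.

Three measured steps exist, and none of them touches that place. Within the data shown here, the first is a step that the two limits leave unreadable from compound 1 to compound 2 with methyl in place of hydrogen on an oxygen next to a carbonyl group. The other two, a step that the two limits leave unreadable from compound 1 to compound 3 and a step that the two limits leave unreadable from compound 2 to compound 3, both change a saturated ring carbon. None of them gives a size to carry over, so no readable step can be expected in this assay in either direction. Compound 4 will most likely be reported as a limit too. The expected outcome is a step that the limit leaves unreadable from compound 1 to compound 4 in this estimate. For compound 4 the estimated value is 30000 nM with an expected range from 12000 nM to 60000 nM.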

Compound 4, half-maximal effective concentration: > 25000 nM
Compound 4: no number, only a limit; the forecaster's own chance of this, stated with the estimate: 85%; the middle value does not contradict the limit.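

In this assay compound 4 gives > 25000 nM, a limit and not a number. Among these compounds, with compound 1 also at a limit, no step for methoxy in place of methyl can be read between compound 1 and compound 4. The compounds shown leave open whether any of these changes alters the read-out, and at what value any of them would give a number: the limit of > 25000 nM in this assay, at which 4 of the 4 values shown sit.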